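A few compounds are considered here, and "the series" means these few. Any claim that something is new, unique, unknown or untested is made for them only; others in the source may bear on it.

Measured compounds:
compound 1 `CCCCCCCCn1nc(-c2cccnc2)c2ccccc2c1=O` — 21900 nM
compound 2 `CCOC(=O)CCCn1nc(-c2cccnc2)c2ccccc2c1=O` — 10000 nM

Both compounds share the same core and differ only in the side chain on the ring nitrogen. In a functional assay (trachea) with Cavia porcellus as the target (on this read-out lower numbers stand for stronger inhibition and higher numbers for weaker inhibition), compound 1 gives 21900 nM, and compound 2 gives 10000 nM. Among the measured compounds shown here, the one measured step, a 2.2-fold lower number from compound 1 to compound 2 (0.34 log units; beyond the scatter), is the only comparison available. Compound 2 thus holds the lowest number of the two measured, separated from compound 1 by a modest step that exceeds the scatter.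

Compound 3 `CC(C)NC(=O)CCCn1nc(-c2cccnc2)c2ccccc2c1=O` is not yet measured. It differs from compound 2 as isopropylamino in place of ethoxy on a carbonyl carbon. For the measured compounds named here, no measured step concerns an exchange at the carbonyl carbon; the step from compound 1 to compound 2 exchanged pentyl for ethoxycarbonyl and does not speak directly to ethoxy against isopropylamino. Going by the values given here, with no bearing step, the expectation is a step in this assay of no more than scatter size, a 1.3-fold lower number from compound 2 to compound 3 (0.10 log units; within the scatter), and compound 3 is estimated at 8000 nM, within the range 3000 nM to 25000 nM.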

Compound 3, half-maximal inhibitory concentration: 64600 nM
Compound 3: the middle estimate sits 8.1-fold (0.91 log units) below what was measured, outside the stated range (above it).
By their numbers in this assay, from the lowest: compound 2; then compound 1; then compound 3.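

In this assay, the group on the carbonyl carbon matters: isopropylamino in place of ethoxy gives a 6.5-fold higher number from compound 2 to compound 3 (0.81 log units; beyond the scatter), a larger move than the earlier 2.2-fold lower number from compound 1 to compound 2 (0.34 log units; beyond the scatter), so the end of this side chain is not a freely exchangeable site. The two carbonyl-bearing chains also fall on opposite sides of the pentyl-ended chain: ethoxycarbonyl lowers the number, whereas isopropylcarbamoyl in place of pentyl gives a 2.9-fold higher number from compound 1 to compound 3 (0.47 log units; beyond the scatter), so a carbonyl group at this place does not by itself lower the number. No available measurement explains the effect of either exchange.

The exchange brings in the amide hydrogen and the isopropyl group together, so these compounds do not show which of the two goes with the higher number; dimethylcarbamoyl, which has no amide hydrogen, and methylcarbamoyl, which keeps it without the isopropyl group, would separate them at this place. Also open, going by these compounds, is how the free carboxylic acid, or the ethyl ester on a shorter or longer chain, would read in this assay.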